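A Butoxy Chain Added to Compound 1

A few compounds are considered here, and "the series" means these few. Any claim that something is new, unique, unknown or untested is made for them only; others in the source may bear on it.

For the measured compounds named here, in a functional assay on MOLT-4 cells (Homo sapiens) for cytotoxicity (a higher number here means a weaker inhibitor, a lower number a stronger inhibitor), compound 1 (`O=S(=O)(N/C(=N\O)Nc1ccc(Cl)cc1)c1ccccc1`) gives 7 ug/mL, the lower of the two numbers so far. Compound 2 (`O=S(=O)(N/C(=N\O)Nc1ccc(Cl)cc1)c1cc2ccccc2s1`) gives 57 ug/mL, clearly higher and beyond the usual scatter. Compound 3 (`CCCCOc1ccc(S(=O)(=O)N/C(=N\O)Nc2ccc(Cl)cc2)cc1`) has butoxy in place of hydrogen on an aromatic carbon of compound 1: butoxy in place of hydrogen on an aromatic carbon. Going by the values given here, no measured pair shows this change, so the only guide is that the one other compound tested, compound 2, reads higher at 57 ug/mL. A modest rise, meaning a somewhat weaker inhibitor, is expected, an estimated 2.0-fold higher number from compound 1 to compound 3 (0.30 log units; within the scatter). For compound 3 the expected value is 14 ug/mL, with an estimated range of 4 ug/mL to 50 ug/mL.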

Compound 3, half-maximal inhibitory concentration: 18 ug/mL
Beside the measured number, compound 3's estimate is 1.3-fold (0.11 log units) below it; the range from low to high includes it.
By their numbers in this assay, from the lowest: compound 1; then compound 3; then compound 2.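

Butoxy in place of hydrogen on this aromatic carbon, para to a large group, gives a weaker inhibitor in this assay (a 2.6-fold higher number from compound 1 to compound 3 (0.41 log units; beyond the scatter)). This first measured step at the position is modest, yet it shows that the added chain raises the number without removing activity. No measurement here explains the rise.

As far as these compounds go, whether methoxy, an amine or a carboxylic acid on the same carbon would read higher or lower remains open. So does whether the chain's length or its oxygen drives the step.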